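Aryl triazole series: trifluoromethyl variant of compound 1

This account rests on a few compounds, and the source may have more. Where it says the series, first, only, none or still open, it means among the compounds named here.

Among the compounds with values here, compound 1 `C=C1C(=O)[C@]23C[C@@]1(O)CC[C@H]2c1ccc(O)c(C)c1[C@@H]3Cn1cc(-c2ccccc2)nn1` gives 750 nM in a functional assay on HL-60 cells (Homo sapiens) for cytotoxicity, read by MTT assay, with a stated time of 4 days (on this read-out higher numbers stand for weaker inhibition and lower numbers for stronger inhibition), the only actual number in this set. Compound 2 `C=C1C[C@]23C[C@@]1(O)CC[C@H]2c1ccc(OS(=O)(=O)c2ccc(C)cc2)c(C)c1[C@@H]3Cn1cc(-c2ccc(OC)cc2)nn1` gives > 20000 nM in this assay, which is a limit of the assay and not a number. Compound 3 `C=C1C[C@]23C[C@@]1(O)CC[C@H]2c1ccc(OS(=O)(=O)c2ccc(C)cc2)c(C)c1[C@@H]3Cn1cc(-c2ccc(C)cc2)nn1` gives > 20000 nM in this assay, again a limit. The step that the two limits leave unreadable from compound 2 to compound 3 is therefore unreadable, because both of its ends sit at the limit of > 20000 nM in this assay, at which 2 of the 3 values shown sit.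

Compound 4 `C=C1C(=O)[C@]23C[C@@]1(O)CC[C@H]2c1ccc(O)c(C)c1[C@@H]3Cn1cc(-c2ccc(C(F)(F)F)cc2)nn1` differs from compound 1 by trifluoromethyl in place of hydrogen on an aromatic carbon. Within the data shown here, no measured step in this assay changes the substituent on the phenyl of the triazole on the core of compound 1; the only step that touches that phenyl, from compound 2 to compound 3, lies on a different core and has no readable size. With no usable comparison, no step beyond the scatter is expected in this assay. Compound 4 is therefore estimated at 750 nM in this assay, with a range of 250 nM to 2500 nM, meaning an expected step of no change at the digits printed from compound 1 to compound 4 (within the scatter).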

Compound 4, half-maximal inhibitory concentration: 720 nM
Beside the measured number, compound 4's estimate is 1.0-fold (0.02 log units) above it; the range from low to high includes it.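

Within the data shown here, on the core of compound 1, trifluoromethyl in place of hydrogen, para to a large group, gives the first readable step on this phenyl in this assay: a 1.0-fold lower number from compound 1 to compound 4 (0.02 log units; within the scatter). The position therefore accepts this group with no change beyond the scatter, on this one substituent only, and the series now holds a measured pair at this place on this core. Nothing on hand bears on a cause for this result.

On these data alone, what an amine or a carboxylic acid at the same place would give on this core stays open. Compound 2 and compound 3 add nothing on this phenyl, since each sits at a limit of the assay and not at a number, and the step between them cannot be read: the limit of > 20000 nM in this assay, at which 2 of the 4 values shown sit.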